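This account rests on a few compounds, and the source may have more. Where it says the series, first, only, none or still open, it means among the compounds named here.

Measured so far:
compound 1, `COc1cc(-c2nn(-c3cccc(NC(=O)c4cccc(C(F)(F)F)c4)c3)cc2-c2ccncc2)ccc1Cl`: > 50000 nM
compound 2, `O=C(Nc1cccc(-n2cc(-c3ccncc3)c(-c3ccc(Cl)c(O)c3)n2)c1)Nc1cc(C(F)(F)F)cc(C(F)(F)F)c1`: 1400 nM
compound 3, `O=C(Nc1cccc(-n2cc(-c3ccncc3)c(-c3ccc(Cl)c(O)c3)n2)c1)Nc1ccc(Cl)c(C(F)(F)F)c1`: 1150 nM

In a functional assay on LOX IMVI cells (Homo sapiens) for inhibition, read by sulforhodamine B assay, with a stated time of 48 h (on this read-out higher numbers stand for weaker inhibition of growth and lower numbers for stronger inhibition of growth), compound 1 gives only a limit, > 50000 nM, and no number. Compound 2 gives 1400 nM in this assay, and compound 3 gives 1150 nM; these two lie within the usual scatter of each other. Compound 1 thus stands at the one limit among the three values shown, (the limit of > 50000 nM in this assay, at which 1 of the 3 values shown sits). Compound 4, `COc1cc(-c2nn(-c3cccc(NC(=O)Nc4ccc(Cl)c(Cl)c4)c3)cc2-c2ccncc2)ccc1Cl`, has yet to be measured in this assay. Against compound 1 the change is (3,4-dichlorophenyl)amino in place of 3-(trifluoromethyl)phenyl on a carbonyl carbon. Since compound 1 sits at a limit, the step from compound 1 to compound 4 can only be expected as a lower bound; it is expected to be an at least 8.3-fold lower number from compound 1 to compound 4 (0.92 log units; beyond the scatter), toward stronger inhibition of growth. For compound 4 in this assay the estimate is 6000 nM, with a range from 1500 nM to 30000 nM.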

Compound 4, concentration for total growth inhibition: 2620 nM
Estimate against measurement, compound 4: 2.3-fold (0.36 log units) above; measured number inside the range.
By their numbers in this assay, from the lowest: compounds 3, 2 and 4 (each within the scatter of the next, the first and the last beyond it). At a limit, above all of these: compound 1.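

In this assay, the change of 3-(trifluoromethyl)phenyl to (3,4-dichlorophenyl)amino on a carbonyl carbon gives an at least 19-fold lower number from compound 1 to compound 4 (1.28 log units; beyond the scatter), the first step read at this position. It turns a limit into a measured number, with the (3,4-dichlorophenyl)carbamoyl group in place of the (3-(trifluoromethyl)phenyl)carbonyl group. The size of the step remains a lower bound, as compound 1 stands at a limit and not at a number: the limit of > 50000 nM in this assay, at which 1 of the 4 values shown sits.

The compounds shown do not separate the entering amino nitrogen from the change in the ring's substituents. Going by these compounds, how a non-aromatic group such as cyclohexylamino would behave on this carbonyl carbon also remains open.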